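The compounds below may be only part of what the source reports. "The series", "measured", "known", "first", "only" and "open" are said of these compounds alone.

Working notes on the series. In a functional assay on HL-60 cells (Homo sapiens) for inhibition, read by CCK-8 assay, with a stated time of 48 h, tested at 20 uM (a higher number here means more inhibition of growth at the concentration tested, a lower number less inhibition of growth), compound 1 (`COc1ccc(Cc2nnc(NC(=O)/C(C#N)=C/c3ccccc3OS(=O)(=O)c3ccccc3[N+](=O)[O-])s2)cc1`) gives 25% and compound 2 (`N#C/C(=C\c1ccccc1OS(=O)(=O)c1ccc([N+](=O)[O-])cc1)C(=O)Nc1nnc(Cc2ccccc2)s1`) gives 20%. Within the data shown here, these two values lie within the usual scatter of each other, so compound 2 cannot be separated from the only other measured compound.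

Compound 3 (`N#C/C(=C\c1ccccc1OS(=O)(=O)c1ccccc1[N+](=O)[O-])C(=O)Nc1nnc(Cc2ccccc2)s1`) is still unmeasured and differs from compound 2 in one place: 2-nitrophenyl in place of 4-nitrophenyl on a sulfonyl sulfur. In words, 2-nitrophenyl stands in place of 4-nitrophenyl on a sulfonyl sulfur. Among the measured compounds shown here, no measured pair isolates this change, so the data give it neither a size nor a direction.

The expected a number 2 percentage points higher from compound 2 to compound 3 (within the scatter) therefore stays within the scatter, with no direction favoured. This expectation rests only on compound 2 at 20% as the starting value. For compound 3 the estimated value in this assay is 22%, with an expected range from 8% to 38%.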

Compound 3, percent growth inhibition at one concentration: 12%
The estimate for compound 3 lay 10 percentage points above the measured number, and the stated range covers the measured number.
By their numbers in this assay, from the lowest: compounds 3, 2 and 1 (each within the scatter of the next, the first and the last beyond it).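

In this assay the exchange of 4-nitrophenyl for 2-nitrophenyl on a sulfonyl sulfur now has a measured size: a number 8 percentage points lower from compound 2 to compound 3 (within the scatter) and so cannot be told apart from no change. Among these compounds, with 2-nitrophenyl held constant, hydrogen in place of methoxy on an aromatic carbon gives a number 13 percentage points lower from compound 1 to compound 3 (beyond the scatter) and is the first step to pass the scatter, though only modestly and at a single concentration. Nothing available bears on the cause of either step.

Open, on these data alone, is whether the methoxy step would hold with 4-nitrophenyl on the sulfonyl sulfur. Also open, as far as these compounds go, is how an amine or a carboxylic acid in place of methoxy on that aromatic carbon would read in this assay and whether either would raise growth inhibition beyond the scatter.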